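This account rests on a few compounds, and the source may have more. Where it says the series, first, only, none or still open, it means among the compounds named here.

Within the data shown here, compound 1 `NCCCc1c[nH]c2c(F)cccc12` is the only compound with a numerical result in an assay on isolated protein (urine) for inhibition of Myeloperoxidase (Homo sapiens), with a stated time of 5 min (a higher number here means a weaker inhibitor, a lower number a stronger inhibitor), where compound 1 gives 24 nM. Compound 2 `NCCCCc1c[nH]c2ccc(C(=O)O)cc12` is reported in this assay only as "not active" (no number reported), without a number. Compound 3 `NC(=O)CCc1c[nH]c2c(F)cccc12` has not yet been measured. It differs from compound 1 by carbamoyl in place of aminomethyl on a saturated chain carbon, two bonds along the chain from an aromatic carbon. Among the measured compounds shown here, no measured pair shows this kind of change, so any step from compound 1 is an expectation: a loss of inhibition, beyond the scatter, is expected, with the step of a 25-fold higher number from compound 1 to compound 3 (1.40 log units; beyond the scatter). Compound 3 is estimated at 600 nM, with a range from 100 nM to 5000 nM.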

Compound 3, half-maximal inhibitory concentration: 271 nM
The estimate for compound 3 lay 2.2-fold (0.35 log units) above the measured number; low and high end bracket the measured number.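

In this assay, carbamoyl in place of aminomethyl on a saturated chain carbon, two bonds along the chain from an aromatic carbon, gives an 11-fold higher number from compound 1 to compound 3 (1.05 log units; beyond the scatter). Among these compounds, this is the first numerical comparison at this position: inhibition falls beyond the scatter, yet compound 3 still gives a number, so the aminomethyl is not required for a measurable result. Nothing at hand explains the loss.

The compounds shown leave open how a hydroxymethyl or a nitrile at this place would compare with aminomethyl and carbamoyl. They also leave open whether the same exchange would give a step of similar size on the core of compound 1 without its fluoro group.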